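Swapping the fused bicyclic on the shared core

The source may report more compounds than this note shows. Statements on the series, on what has been measured and on what is new or still open speak of the compounds shown alone.

Compound 1 `O=C1CCC(=O)N1Cc1cc2nccc(-c3cc(Cl)cc4c3O[C@@H](c3onc5c3CNCC5)C4)c2s1`: 0.38 nM
Compound 2 `O=C([C@H]1Cc2cc(Cl)cc(-c3ccnc4cc(C(O)(CO)CCl)sc34)c2O1)N1CCNCC1`: 9 nM

In an assay on isolated protein for inhibition of ubiquitin carboxyl-terminal hydrolase 7 (Homo sapiens), read by fluorescence, with stated times of 30 min and 1 h (on this read-out higher numbers stand for weaker inhibition and lower numbers for stronger inhibition), compound 1 gives the lowest of the two numbers; compound 2 gives a number well beyond the scatter higher. Compound 3 `Cn1nc2c(c1[C@H]1Cc3cc(Cl)cc(-c4ccnc5cc(CN6C(=O)CCC6=O)sc45)c3O1)CNCC2` has not been measured. It differs from compound 1 by a group of 10 heavy atoms (7 carbon, 3 nitrogen; one five-membered aromatic ring with 2 hetero atoms, one six-membered non-aromatic ring with 1 hetero atom) in place of a group of 9 heavy atoms (6 carbon, 2 nitrogen, 1 oxygen; one five-membered aromatic ring with 2 hetero atoms, one six-membered non-aromatic ring with 1 hetero atom), on a saturated ring carbon. Among the measured compounds shown here, no measured pair isolates this change, so the expectation rests on how alike the two groups are. The step of a 1.6-fold higher number from compound 1 to compound 3 (0.20 log units; within the scatter) is expected to be small, not beyond the scatter, in either direction. Compound 3 is therefore estimated at 0.6 nM, with a range from 0.15 nM to 3 nM.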

Compound 3, half-maximal inhibitory concentration: 1.1 nM
Beside the measured number, compound 3's estimate is 1.8-fold (0.26 log units) below it; the range from low to high includes it.
By their numbers in this assay, from the lowest: compound 1; then compound 3; then compound 2.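

On the saturated ring carbon next to the ring oxygen, the two fused groups have the same ring types and the same counts of donors and acceptors, yet in this assay they are not interchangeable: the swap gives a 2.9-fold higher number from compound 1 to compound 3 (0.46 log units; beyond the scatter). The step is modest, so this position accepts either fused group with only a limited shift. Nothing shown accounts for the difference.

Still open, as far as these compounds go, is whether this carbon needs a fused group at all. A simple primary amine or a carboxylic acid in that place would test this.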